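A few compounds are considered here, and "the series" means these few. Any claim that something is new, unique, unknown or untested is made for them only; others in the source may bear on it.

Compound 1 `CCOC(=O)N1CCN(Cc2c(O)c([C@H]3CCN(C)C[C@H]3O)c3oc(C)cc(=O)c3c2O)CC1`: 1%
Compound 2 `Cc1oc2c([C@H]3CCN(C)C[C@H]3O)c(O)cc(O)c2c(=O)c1C(O)c1cccc(Cl)c1`: 31%

Both values come from a functional assay on PC-3 cells (Homo sapiens) for inhibition, read by MTT assay, with a stated time of 48 h, tested at 10 uM; a higher number here means more inhibition of growth at the concentration tested, a lower number less inhibition of growth. Of the two, compound 2 stands highest at 31%, while compound 1 gives 1%, a gap beyond the usual scatter. Even so, compound 2 leaves most growth uninhibited at the concentration tested. These two compounds differ in more than one place, so no single structural change has yet been measured on its own.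

Compound 3 `Cc1oc2c([C@H]3CCN(C)C[C@H]3O)c(O)cc(O)c2c(=O)c1C(O)c1csc([N+](=O)[O-])c1` has not been measured. It keeps the core of compound 2 and changes one group: 5-nitrothiophen-3-yl in place of 3-chlorophenyl on a saturated chain carbon bound to an aromatic carbon and an oxygen on a saturated carbon. Put simply, 5-nitrothiophen-3-yl stands in place of 3-chlorophenyl on a saturated chain carbon bound to an aromatic carbon and an oxygen on a saturated carbon.

For the measured compounds named here, no measured step shows what this exchange does, so the best guide is compound 2 itself, at 31%. The expectation is therefore a small step, slightly downward if anything and not beyond the scatter. The expected change is a number 4 percentage points lower from compound 2 to compound 3 (within the scatter). For compound 3, the estimated value is 27%, with an expected range from 8% to 50%.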

Compound 3, percent growth inhibition at one concentration: 0%
The estimate for compound 3 lay 27 percentage points above the measured number; the whole stated range lies above it.
By their numbers in this assay, from the lowest: compounds 3 and 1 (each within the scatter of the next); then compound 2.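

For the compounds shown here, the first single-place comparison in this set concerns the group on a saturated chain carbon bound to an aromatic carbon and an oxygen on a saturated carbon. In this assay, putting 5-nitrothiophen-3-yl in place of 3-chlorophenyl there gives a number 31 percentage points lower from compound 2 to compound 3 (beyond the scatter). This shows that the position is not indifferent to what it carries: with the rest of the molecule unchanged, the choice of this one ring group separates the modest inhibition of growth seen for compound 2 from the absence of any inhibition seen for compound 3, and no measurement at hand gives a reason for that loss.

The exchange alters several features at once, replacing a six-membered carbon ring with a five-membered ring containing sulfur, and swapping chlorine for a nitro group, so the compounds shown cannot tell which of these features matters. A plain phenyl, a thiophen-3-yl without the nitro group, or a phenyl carrying a nitro group would pull these features apart, and an amine on the ring would show whether this position can carry a different kind of group.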